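One Added Hydroxy, Followed Through a Cytotoxicity Assay

The source may report more compounds than this note shows. Statements on the series, on what has been measured and on what is new or still open speak of the compounds shown alone.

Measured in a functional assay on T47D cells (Homo sapiens) for cytotoxicity, read by MTT assay; on this read-out higher numbers stand for weaker inhibition and lower numbers for stronger inhibition:
compound 1 `COc1ccc(/C=C/C(=O)c2ccc(O)cc2)cc1Br`: "not determined" (no result reported)
compound 2 `COc1ccc(/C=C/C(=O)c2ccc(F)cc2)cc1Br`: > 25000 nM
compound 3 `COc1cc(O)ccc1/C=C/C(=O)c1ccc(N)cc1`: "not determined" (no result reported)

The starting point has no number to lean on. In this assay compound 1 gives "not determined" (no result reported), and compound 3 also gives "not determined" (no result reported). Within the data shown here, the only reading in this small set is the limit of > 25000 nM in this assay, at which 1 of the 3 values shown sits. Compound 2 shows > 25000 nM, which is a limit of the assay and not a number.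

The compound still to be tested is compound 4 `COc1ccc(/C=C/C(=O)c2ccc(O)cc2O)cc1Br`. The change is hydroxy in place of hydrogen on an aromatic carbon, ortho to a large group and meta to a hydroxy group.

Among the measured compounds shown here, no pair of measured compounds shows what such a change does, so the data give neither a size nor a direction for it. The expected step in this assay is therefore none beyond the usual scatter. This expectation leans on compound 2 alone, whose > 25000 nM is a limit. For compound 4 the estimated value is 20000 nM, with an expected range from 5000 nM to 80000 nM.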

Compound 4, half-maximal inhibitory concentration: 1050 nM
Estimate against measurement, compound 4: 19-fold (1.28 log units) above; the measured number lies below the stated range.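

In this assay compound 1 gives "not determined" (no result reported) and so no step can be read between compound 1 and compound 4. Whether the added hydroxy changes cytotoxicity, and in which direction, stays open, and the only other reading here is a limit: the limit of > 25000 nM in this assay, at which 1 of the 4 values shown sits.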